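A few compounds are considered here, and "the series" means these few. Any claim that something is new, unique, unknown or untested is made for them only; others in the source may bear on it.

Of the compounds shown here, three have so far been tested in an ADME assay on Akata cells (Homo sapiens) for cytotoxicity, with a stated time of 7 days; a higher number here means that more compound is tolerated, a lower number that less compound is tolerated. Compound 1 `Nc1nc2c(ncn2/C=C2/CC2(CO)CO)c(=O)[nH]1` gives > 20000 nM, which is a limit of the assay rather than a number. Compound 2 `Nc1nc(N2CCCC2)c2ncn(/C=C3/CC3(CO)CO)c2n1` gives > 24000 nM, again a limit. Compound 3 `CC(C)CNc1nc(N)nc2c1ncn2/C=C1/CC1(CO)CO` gives > 24000 nM, also a limit. Compound 2 therefore stands at a limit, and the other two values shown do likewise: the three results fall at the limit of > 20000 nM in this assay, at which 1 of the 3 values shown sits, and at the limit of > 24000 nM in this assay, at which 2 of the 3 values shown sit. For the measured compounds named here, the only step between measured compounds that differ in one place, a step that the two limits leave unreadable from compound 2 to compound 3, cannot be given a size because both ends are limits.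

Compound 4 `CCCCCCOc1nc(N)nc2c1ncn2/C=C1/CC1(CO)CO` differs from compound 2 by hexyloxy in place of pyrrolidin-1-yl on an aromatic carbon. Going by the values given here, no measured step bears on this change with a readable size, and nothing among the three results separates one compound from another beyond the scatter. The expected step in this assay is a number no higher from compound 2 to compound 4 (the limit leaves the size open), that is, none beyond the scatter. Compound 4 is accordingly estimated at 24000 nM, within a range of 10000 nM to 60000 nM, most likely reported again as a limit.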

Compound 4, half-maximal cytotoxic concentration: > 20000 nM
Compound 4: no number, only a limit; the forecaster's own chance of this, stated with the estimate: 80%; the middle value is on the limit's open side.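

In this assay compound 4 gives > 20000 nM, a limit of the assay, and the steps to it from compound 2 and compound 3 cannot be read. The compounds shown leave open whether hexyloxy, pyrrolidin-1-yl and isobutylamino differ at all in this assay, and at what concentration any of these compounds becomes cytotoxic.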